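This account rests on a few compounds, and the source may have more. Where it says the series, first, only, none or still open, it means among the compounds named here.

Compound 2 `Nc1scc(-c2ccc(Cl)cc2)c1C(=O)c1ccccc1` gives 46% in a functional assay on CHO cells for agonist activity at adenosine receptor A1 (Homo sapiens), read by fluorescence and ERK phosphorylation, with stated times of 30 min and 1.5 h, tested at 3 uM; a lower number here means a weaker effect, a higher number a stronger effect of the compound at the concentration tested. Of the three numbers measured it is the lowest, though neither neighbour is separated from it beyond the scatter: compound 3 `Nc1scc(-c2ccc([N+](=O)[O-])cc2)c1C(=O)c1ccccc1` gives 50%, and compound 1 `Nc1scc(-c2cccc(F)c2)c1C(=O)c1ccccc1` gives 51%. The two measured steps, a number 5 percentage points lower from compound 1 to compound 2 (within the scatter) and a number 4 percentage points higher from compound 2 to compound 3 (within the scatter), both lie within the scatter, and both alter the substituent on the aryl ring that sits on the shared core, not the phenyl of the carbonyl. Compound 4 `Nc1scc(-c2ccc(Cl)cc2)c1C(=O)c1ccc(Cl)cc1` has not yet been measured. It differs from compound 2 by chloro in place of hydrogen on an aromatic carbon. Among the measured compounds shown here, no measured step touches this phenyl, so the only guidance is the flatness of the series so far, in which substituent changes on the other ring moved nothing beyond the scatter. The account therefore expects no step beyond the scatter, which it writes as no change at the digits printed from compound 2 to compound 4 (within the scatter). The estimate for compound 4 is 46%, with a range from 30% to 62%.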

Compound 4, a percentage reported as activity, at one concentration (the size of the read-out at that concentration, not a potency): 50%
Beside the measured number, compound 4's estimate is 4 percentage points below it; measured number inside the range.
By their numbers in this assay, from the lowest: compounds 2, 3, 4 and 1 (each within the scatter of the next).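

Among the compounds shown here, this is the first measured change on the phenyl of the carbonyl rather than on the other aryl ring, and in this assay the change from phenyl to 4-chlorophenyl, para to a large group, gives a small step (a number 4 percentage points higher from compound 2 to compound 4 (within the scatter)). A chloro at this position therefore leaves the read-out within the scatter, so the flatness seen on the other aryl ring extends to this one change on the second ring. Nothing measured here offers an explanation for this result.

The compounds shown leave open whether other groups on this phenyl, such as an amine, a carboxylic acid or a methoxy group, would also stay within the scatter. They also leave open whether a chloro elsewhere on this ring would behave as this one does.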